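From 4-Hydroxyphenyl to 4-Fluorophenyl at the Assay Limit

This account rests on a few compounds, and the source may have more. Where it says the series, first, only, none or still open, it means among the compounds named here.

Measured in a functional assay on MCF-A cells (Homo sapiens) for cytotoxicity; a higher number here means a weaker inhibitor of growth, a lower number a stronger inhibitor of growth:
Compound 1 `COc1ccc(C2=C(c3ccc(SC)cc3)CC3CCCN3C2=O)cc1O`: 5000 nM
Compound 2 `CSc1ccc(C2=C(c3ccc(F)c(F)c3)C(=O)N3CCCC3C2)cc1`: 800 nM
Compound 3 `CSc1ccc(C2=C(c3ccc(O)cc3)C(=O)N3CCCC3C2)cc1`: > 100000 nM

In this assay compound 3 gives only a limit, > 100000 nM, and no number. Compound 4 `CSc1ccc(C2=C(c3ccc(F)cc3)C(=O)N3CCCC3C2)cc1` differs from it in one place: fluoro in place of hydroxy on an aromatic carbon. Its 4-hydroxyphenyl becomes 4-fluorophenyl, with fluoro in place of hydroxy on an aromatic carbon.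

Going by the values given here, two measured steps bear on this change, and both end at compound 3. The closer one starts from the 3,4-difluorophenyl of compound 2, giving an at least 120-fold higher number from compound 2 to compound 3 (2.09 log units; beyond the scatter). The other starts from the 3-hydroxy-4-methoxyphenyl of compound 1, giving an at least 20-fold higher number from compound 1 to compound 3 (1.30 log units; beyond the scatter). Among the compounds with values here, both are large, but neither has an exact size, and no compound with a single fluoro has been measured. Leaving the 4-hydroxyphenyl is therefore expected to bring a large move to a lower number, with compound 2 at 800 nM as the nearest guide. The expected change is an at least 66-fold lower number from compound 3 to compound 4 (1.82 log units; beyond the scatter). For compound 4 the estimate is 1500 nM, with an expected range of 300 nM to 8000 nM.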

Compound 4, concentration for 50% growth inhibition: 800 nM
Estimate against measurement, compound 4: 1.9-fold (0.27 log units) above; low and high end bracket the measured number.
By their numbers in this assay, from the lowest: compounds 2 and 4 (each within the scatter of the next); then compound 1. At a limit, above all of these: compound 3.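

In this assay, replacing hydroxy with fluoro gives an at least 120-fold lower number from compound 3 to compound 4 (2.09 log units; beyond the scatter), showing that a single fluoro on this aromatic carbon, para to a large group, is enough to leave the limit. Compound 3 gives only a limit, so this step has a lower bound and no exact size: the limit of > 100000 nM in this assay, at which 1 of the 4 values shown sits. Going from the 3,4-difluorophenyl to the 4-fluorophenyl brings no change at the digits printed from compound 2 to compound 4 (within the scatter), so the second fluoro makes no difference that can be read here, while the 4-fluorophenyl still gives a 6.3-fold lower number from compound 1 to compound 4 (0.80 log units; beyond the scatter).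

The compounds shown leave open whether fluoro itself matters or whether losing the hydroxy is enough: a plain phenyl, a 4-chlorophenyl or a 4-methoxyphenyl would help to separate the two. Going by these compounds, the exact size of the step from the 4-hydroxyphenyl also remains unknown.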